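The source may report more compounds than this note shows. Statements on the series, on what has been measured and on what is new or still open speak of the compounds shown alone.

Measured so far in a functional assay on MCF7 cells (Homo sapiens) for inhibition, read by sulforhodamine B assay, with a stated time of 72 h; a higher number here means a weaker inhibitor, a lower number a stronger inhibitor:
compound 1 `COc1cc(OC)c(C(=O)/C=C/c2cn(-c3ccccc3)nc2-c2ccsc2)c(OC)c1` gives 2700 nM
compound 2 `COc1ccc(C(=O)/C=C/c2cn(-c3ccccc3)nc2-c2ccsc2)c(OC)c1` gives 9000 nM
compound 3 `O=C(/C=C/c1cn(-c2ccccc2)nc1-c1ccncc1)c1ccsc1` gives 1500 nM

Compound 1 stands second highest of the three numbers in this assay. Its nearest neighbour is compound 3, and that gap lies within the scatter, so no order between the two is claimed. Within the data shown here, compound 2 is furthest, and that pair is the only single-place step in the set: a 3.3-fold higher number from compound 1 to compound 2 (0.52 log units; beyond the scatter), hydrogen in place of methoxy on an aromatic carbon.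

Compound 4 `COc1cc(OC)c(C(=O)/C=C/c2cn(-c3ccccc3)nc2-c2ccncc2)c(OC)c1` differs from compound 1 by pyridin-4-yl in place of thiophen-3-yl on an aromatic carbon. Among the measured compounds shown here, no measured step changes that position alone. For the measured compounds named here, compound 3 carries pyridin-4-yl and gives 1500 nM in this assay, but it also differs from compound 1 on the ketone side, so its pair with compound 1 shows only that the two values sit within the scatter. The methoxy step from compound 1 to compound 2 does not bear on this exchange. The expectation for compound 4 is therefore no step beyond the scatter in this assay, estimated as a 1.2-fold lower number from compound 1 to compound 4 (0.09 log units; within the scatter). Compound 4 is expected at 2200 nM, with a range of 800 nM to 6500 nM.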

Compound 4, half-maximal inhibitory concentration: 1600 nM
The estimate for compound 4 lay 1.4-fold (0.14 log units) above the measured number; low and high end bracket the measured number.
By their numbers in this assay, from the lowest: compounds 3, 4 and 1 (each within the scatter of the next); then compound 2.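

In this assay, the place next to the ring nitrogen now has its first single-place exchange: pyridin-4-yl in place of thiophen-3-yl gives a 1.7-fold lower number from compound 1 to compound 4 (0.23 log units; within the scatter) and so does not separate the two groups on the core of compound 1. Among these compounds, a six-membered aromatic ring with nitrogen as its hetero atom therefore stands here without a step beyond the scatter, while the only such step in the set remains the methoxy change, a 3.3-fold higher number from compound 1 to compound 2 (0.52 log units; beyond the scatter). Nothing measured ties this result to any property of either group.

As far as these compounds go, how a dimethylamino group, a carboxylic acid or a plain methyl would read at this place stays open. Also open, from the compounds shown here alone, is whether the same exchange would read alike on the core of compound 2.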